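Aryl swap on sulfur: compound 3 to compound 4

The source may report more compounds than this note shows. Statements on the series, on what has been measured and on what is new or still open speak of the compounds shown alone.

In a functional assay on SMMC-7721 cells (Homo sapiens) for inhibition, read by CCK-8 assay, with a stated time of 72 h, tested at 8 uM (on this read-out lower numbers stand for less inhibition of growth and higher numbers for more inhibition of growth at the one concentration tested), compound 1 `Cc1cc(C)cc(SCc2ccc(/C=C/C(=O)Nc3ccccc3N)cc2)c1` gives 7.13%, compound 2 `Nc1ccccc1NC(=O)/C=C/c1ccc(CSc2ccc(Cl)cc2)cc1` gives 16.5% and compound 3 `Nc1ccccc1NC(=O)/C=C/c1ccc(CSc2cccc(F)c2)cc1` gives 8.25%. Compound 3 thus stands among three values that the scatter does not separate.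

The next change leads to compound 4 `Nc1ccccc1NC(=O)/C=C/c1ccc(CSc2ccc(C(F)(F)F)cn2)cc1`: 5-(trifluoromethyl)pyridin-2-yl in place of 3-fluorophenyl on a sulfur. In words, 5-(trifluoromethyl)pyridin-2-yl comes in place of 3-fluorophenyl on a sulfur. For the measured compounds named here, the incoming group is a six-membered aromatic ring with 1 hetero atom, and no measured compound carries a hetero atom in the group at this place.

Three measured steps change the group on this sulfur: a number 9.4 percentage points higher from compound 1 to compound 2 (within the scatter), a number 1.1 percentage points higher from compound 1 to compound 3 (within the scatter) and a number 8.3 percentage points lower from compound 2 to compound 3 (within the scatter). On these data alone, all stay within the scatter, so no step beyond the scatter is expected here, and the direction remains open. The expected step is a number 2.8 percentage points higher from compound 3 to compound 4 (within the scatter), which is within the scatter. For compound 4 the estimated value is 11%, with an expected range of 2% to 24%.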

Compound 4, percent growth inhibition at one concentration: 20.1%
Beside the measured number, compound 4's estimate is 9.1 percentage points below it; low and high end bracket the measured number.
By their numbers in this assay, from the lowest: compounds 1, 3, 2 and 4 (each within the scatter of the next, the first and the last beyond it).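

In this assay, for the compounds shown here, the 5-(trifluoromethyl)pyridin-2-yl group gives a number 11.9 percentage points higher from compound 3 to compound 4 (beyond the scatter) and also a number 13 percentage points higher from compound 1 to compound 4 (beyond the scatter) as the first steps on this sulfur beyond the scatter. The same group gives a number 3.6 percentage points higher from compound 2 to compound 4 (within the scatter) against 4-chlorophenyl, so it separates from 3-fluorophenyl and 3,5-dimethylphenyl but not from every carbon-only aryl group in the series. Nothing measured here accounts for these steps.

The ring nitrogen and the trifluoromethyl group enter together, so the compounds shown do not tell which of them goes with the higher number; a plain pyridinyl ring and a phenyl ring carrying trifluoromethyl would divide the two. Also open, on these data alone, is how a saturated amine such as morpholine or a carboxylic acid on this sulfur would read.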